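Methyl in place of vinyl on the aromatic carbon

The compounds below may be only part of what the source reports. "The series", "measured", "known", "first", "only" and "open" are said of these compounds alone.

Values in a functional assay (muscle tissue) with Cavia porcellus as the target; a higher number here means that more compound is needed for the effect, a lower number that less compound is needed:
- compound 1 `CCOc1ccccc1C1C(C(=O)OC)=C(C)N=C(C)/C1=C(\O)OC` gives 110 nM
- compound 2 `C=Cc1ccccc1C1C(C(=O)OC)=C(C)N=C(C)/C1=C(\O)OC` gives 4.47 nM
- compound 3 `COC(=O)C1=C(C)N=C(C)/C(=C(\O)OC)C1c1ccccc1C` is not yet measured

Compound 2 holds the lower of the two numbers. The change to compound 3 is methyl in place of vinyl on an aromatic carbon, ortho to a large group. Among the measured compounds shown here, one measured step bears on it: a 25-fold lower number from compound 1 to compound 2 (1.39 log units; beyond the scatter), a large change involving vinyl but not methyl. A moderate rise is therefore expected in this assay, though its size is poorly defined. The expected step is a 5.6-fold higher number from compound 2 to compound 3 (0.75 log units; beyond the scatter). The estimate for compound 3 is 25 nM, with an expected range of 6 nM to 100 nM.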

Compound 3, half-maximal effective concentration: 6.03 nM
For compound 3 the middle estimate is 4.1-fold (0.62 log units) above the measured one; the range from low to high includes it.
By their numbers in this assay, from the lowest: compounds 2 and 3 (each within the scatter of the next); then compound 1.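

Vinyl can be replaced by methyl on this aromatic carbon in this assay with a 1.3-fold higher number from compound 2 to compound 3 (0.13 log units; within the scatter) and so the second carbon and the double bond of vinyl are not required for the low number. Methyl also gives an 18-fold lower number from compound 1 to compound 3 (1.26 log units; beyond the scatter) and so the large drop from ethoxy is not peculiar to vinyl. No evidence on the cause of either step is at hand.

Left open is whether methoxy, chlorine or an amine on this aromatic carbon would fall with compound 1 or with compound 2 and compound 3, and whether a longer chain such as propyl keeps the low number. The compounds shown also do not separate the oxygen of ethoxy from its chain length.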